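Working notes on the step from compound 3 to compound 4

A few compounds are considered here, and "the series" means these few. Any claim that something is new, unique, unknown or untested is made for them only; others in the source may bear on it.

Measured so far:
- compound 1, `CN(C)c1ncnc2c1ncn2Cc1ccc(C#N)cc1`: in a functional assay on the whole organism for inhibition, with Rattus norvegicus as the target, at a dose of 25 mg/kg by the intraperitoneal route (a higher number here means more inhibition at the dose given (going by the name of the read-out), a lower number less inhibition), compound 1 gives 0%
- compound 2, `Cc1cccc(Cn2cnc3c(N(C)C)ncnc32)c1`: in this assay compound 2 gives 12%
- compound 3, `CN(C)c1ncnc2c1ncn2Cc1ccccc1[N+](=O)[O-]`: in this assay compound 3 gives 0%

All three share one core and differ only in the group on the benzyl ring. Compound 3 stands level with compound 1 at the digits recorded; the two are together the lowest of the three numbers, and the gap between them is within the scatter, so no order is claimed between them. Compound 2 lies higher than compound 3, and that gap is beyond the scatter. For the measured compounds named here, with only three compounds, no pattern between the substituent and the read-out is drawn.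

Compound 4, `CN(C)c1ncnc2c1ncn2Cc1ccccc1N`, has not yet been measured in this assay. It differs from compound 3 in one place: amino in place of nitro on an aromatic carbon.

Going by the values given here, no step between two measured compounds matches this change, so the expected direction rests only on the low reading of compound 3 at 0%. The step from compound 3 to compound 4 is expected to be small, a number 5 percentage points higher from compound 3 to compound 4 (within the scatter), and likely within the scatter. Compound 4 is therefore estimated at 5%, with a range from 0% to 20%.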

Compound 4, a percentage reported as inhibition, in the whole organism at one dose (the size of the read-out at that dose, not a potency): 0%
Compound 4: the middle estimate sits 5 percentage points above what was measured; the range from low to high includes it.
By their numbers in this assay, from the lowest: compounds 1, 3 and 4 (each within the scatter of the next); then compound 2.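

In this assay, amino in place of nitro on an aromatic carbon, ortho to a large group, gives no change at the digits printed from compound 3 to compound 4 (within the scatter). For the compounds shown here, this is the first readable step, and it shows that this exchange does not separate the two groups at this dose, although the entering group carries a hydrogen-bond donor and fewer heavy atoms than the nitro it replaces. With compound 4 at 0%, neither group on this carbon lifts the reading, and nothing measured bears on why the reading stays there.

As far as these compounds go, whether a methyl, a methoxy or a carboxylic acid on this same carbon would give a different reading remains open. Also open, from the compounds shown here alone, is whether an acetamide or a longer chain built on the amino group would change the reading of compound 4 in this assay at all.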